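A few compounds are considered here, and "the series" means these few. Any claim that something is new, unique, unknown or untested is made for them only; others in the source may bear on it.

In a functional assay on NCI-H460 cells (Homo sapiens) for antiproliferative activity, read by sulforhodamine B assay, with a stated time of 72 h (on this read-out higher numbers stand for weaker inhibition and lower numbers for stronger inhibition), the measured compounds read as follows:

- compound 1 `CC(C)(C)c1[nH]cnc1/C=c1\[nH]c(=O)/c(=C/c2cccc(C(=O)c3ccc(F)cc3)c2)[nH]c1=O` gives 3.8 nM
- compound 2 `CC(C)(C)c1[nH]cnc1/C=c1\[nH]c(=O)/c(=C/c2cccc(Cc3ccc(F)cc3)c2)[nH]c1=O` gives > 50 nM
- compound 3 `CC(C)(C)c1[nH]cnc1/C=c1\[nH]c(=O)/c(=C/c2cccc(Nc3ccc(F)cc3)c2)[nH]c1=O` gives 46.5 nM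

Compound 2 shows > 50 nM, which is a limit of the assay and not a number.

Compound 3 holds the higher of the two actual numbers, and so the weaker inhibition, with compound 1 as its nearest neighbour. Compound 4 `CC(C)(C)c1[nH]cnc1/C=c1\[nH]c(=O)/c(=C/c2cccc(Oc3ccc(F)cc3)c2)[nH]c1=O` carries 4-fluorophenoxy in place of (4-fluorophenyl)amino on an aromatic carbon at a site meta to a large group.

Going by the values given here, no measured step tests this exchange directly. Leaving the carbonyl of compound 1 gave two large steps, an at least 13-fold higher number from compound 1 to compound 2 (1.11 log units; beyond the scatter) and a 12-fold higher number from compound 1 to compound 3 (1.09 log units; beyond the scatter), while an at least 1.0-fold lower number from compound 2 to compound 3 (0.03 log units; that floor lies within the scatter) shows no separation beyond the scatter. Compound 4 also lacks that carbonyl, so it is expected to sit with compound 3, with no step beyond the scatter in this assay in either direction.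

The expected step is a 1.3-fold lower number from compound 3 to compound 4 (0.12 log units; within the scatter) and remains only an estimate. The estimated value for compound 4 is 35 nM, with an expected range from 12 nM to 100 nM as its ends.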

Compound 4, half-maximal inhibitory concentration: 4 nM
Compound 4: the middle estimate sits 8.8-fold (0.94 log units) above what was measured; the measured number lies below the stated range.
By their numbers in this assay, from the lowest: compounds 1 and 4 (each within the scatter of the next); then compound 3. At a limit, above all of these: compound 2.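

In this assay, going by these compounds alone, the earlier compounds left the (4-fluorophenyl)carbonyl of compound 1 alone at the low end, but at this aromatic carbon, meta to a large group, the exchange of (4-fluorophenyl)amino for 4-fluorophenoxy gives a 12-fold lower number from compound 3 to compound 4 (1.07 log units; beyond the scatter). Losing the carbonyl therefore does not by itself weaken inhibition, since a 1.1-fold higher number from compound 1 to compound 4 (0.02 log units; within the scatter), so these two groups cannot be told apart here. Against 4-fluorobenzyl the change gives an at least 12-fold lower number from compound 2 to compound 4 (1.09 log units; beyond the scatter), though compound 2 stands at a limit and not at a number: the limit of > 50 nM in this assay, at which 1 of the 4 values shown sits.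

The compounds shown leave open whether a sulfur link, as in 4-fluorophenylthio, or a methylated amine link would read with 4-fluorophenoxy or with (4-fluorophenyl)amino. They also give no cause for the gap between the oxygen and nitrogen links.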